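Furan-2-yl in place of 4-hydroxyphenyl on the thiosemicarbazone

A few compounds are considered here, and "the series" means these few. Any claim that something is new, unique, unknown or untested is made for them only; others in the source may bear on it.

Compound 1 `CC1=CC[C@H](C(C)(C)NC(=S)N/N=C/c2ccc(O)cc2)CC1` is the reference of this set. In a functional assay on K562 cells (Homo sapiens) for inhibition, read by sulforhodamine B assay, with a stated time of 48 h (on this read-out lower numbers stand for stronger inhibition of growth and higher numbers for weaker inhibition of growth), compound 1 gives > 100000 nM, which is a limit of the assay and not a number; compound 1 thus stands at the limit of > 100000 nM in this assay, at which 1 of the 3 values shown sits. Compound 2 `CC1=CC[C@H](C(C)(C)NC(=S)N/N=C/c2ccc(N(C)C)cc2)CC1` gives 22600 nM in this assay, and compound 3 `COc1cc(/C=N/NC(=S)NC(C)(C)[C@H]2CC=C(C)CC2)ccc1O` gives 1900 nM. Both steps away from compound 1 run toward lower numbers: an at least 4.4-fold lower number from compound 1 to compound 2 (0.64 log units; beyond the scatter) and an at least 52-fold lower number from compound 1 to compound 3 (1.72 log units; beyond the scatter).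

Compound 4 `CC1=CC[C@H](C(C)(C)NC(=S)N/N=C/c2ccco2)CC1` differs from compound 1 by furan-2-yl in place of 4-hydroxyphenyl on a carbon with a double bond to nitrogen. Within the data shown here, no measured pair carries this replacement. Among the measured compounds shown here, the two measured steps show only that changes on the aromatic part of compound 1 move the number off the limit, the smaller move in an at least 4.4-fold lower number from compound 1 to compound 2 (0.64 log units; beyond the scatter) and the larger in an at least 52-fold lower number from compound 1 to compound 3 (1.72 log units; beyond the scatter). A step of modest size downward is therefore expected, with a clear chance that this assay again reports only a limit. For compound 4 the expected value in this assay is 30000 nM, with a range from 5000 nM to 150000 nM. The expected step of an at least 3.3-fold lower number from compound 1 to compound 4 (0.52 log units; beyond the scatter) is thus a modest one.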

Compound 4, concentration for 50% growth inhibition: 100 nM
Compound 4: the middle estimate sits 300-fold (2.48 log units) above what was measured; the measured number lies below the stated range.
By their numbers in this assay, from the lowest: compound 4; then compound 3; then compound 2. At a limit, above all of these: compound 1.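

The earlier steps shown here all kept the six-membered aromatic ring of carbon only, whereas this change replaces that ring itself with a five-membered aromatic ring with 1 hetero atom, and in this assay it gives an at least 1000-fold lower number from compound 1 to compound 4 (3.00 log units; beyond the scatter). Compound 1 sits at a limit, so the size of this step is only a lower bound: the limit of > 100000 nM in this assay, at which 1 of the 4 values shown sits. The change also removes the hydroxy group, so this single step cannot separate the exchange of ring from the loss of that group.

Open, on these data alone, is whether the ring oxygen of furan-2-yl matters, which thiophen-2-yl, pyrrol-2-yl or an unsubstituted phenyl on the same carbon would help to settle. Also open, as far as these compounds go, is how the number in this assay responds to a methyl group or a chlorine on the furan ring.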